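Working notes: estimating the 1,3-thiazol-2-yl analogue of compound 3

The compounds below may be only part of what the source reports. "The series", "measured", "known", "first", "only" and "open" are said of these compounds alone.

Measured so far in a physicochemical assay for lipophilicity; a higher number here means a more lipophilic compound, a lower number a more polar compound:
compound 1, `O=S(=O)(Nc1nccs1)c1ccc2c(c1)OCC[C@H]2c1ccc(C(F)(F)F)cc1-n1ccnn1`, gives 2.3.
compound 2, `O=S(=O)(Nc1nccs1)c1ccc2c(c1)OCC[C@@H]2c1ccc(C(F)(F)F)cc1-c1nccs1`, gives 3.3.
compound 3, `O=S(=O)(Nc1nccs1)c1ccc2c(c1)OCC[C@H]2c1ccc(C(F)(F)F)cc1-c1ccc(F)cc1`, gives 4.5.

Compound 3 stands highest of the three numbers in this assay; compound 2 is nearest and compound 1 furthest, both gaps beyond the scatter. Within the data shown here, the only single-point step measured so far is a number 2.20 log units higher from compound 1 to compound 3 (beyond the scatter), a large rise on exchanging 1H-1,2,3-triazol-1-yl for 4-fluorophenyl on that aromatic carbon.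

Compound 4, `O=S(=O)(Nc1nccs1)c1ccc2c(c1)OCC[C@H]2c1ccc(C(F)(F)F)cc1-c1nccs1`, is not yet measured. It differs from compound 3 by 1,3-thiazol-2-yl in place of 4-fluorophenyl on an aromatic carbon. Among the measured compounds shown here, no measured step covers this exact exchange. Two things bear on it: the step from compound 1 to compound 3 shows how much the 4-fluorophenyl group adds over a five-membered ring with hetero atoms on this aromatic carbon, and compound 2, which carries the same 1,3-thiazol-2-yl group on the same aromatic carbon, gives 3.3 in this assay. A downward step, beyond the scatter, is therefore expected, landing compound 4 close to the number of compound 2. The expected step is a number 1.20 log units lower from compound 3 to compound 4 (beyond the scatter). The estimate for compound 4 in this assay is 3.3, with a range of 3 to 3.6.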

Compound 4, distribution coefficient: 3.3
Compound 4: the middle estimate sits on the measured number at the digits printed; measured number inside the range.
By their numbers in this assay, from the lowest: compound 1; then compounds 2 and 4 (each within the scatter of the next); then compound 3.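

In this assay, the exchange on this aromatic carbon can now be read from compound 4 in both directions, with a number 1.20 log units lower from compound 3 to compound 4 (beyond the scatter) and a number 1.00 log units higher from compound 1 to compound 4 (beyond the scatter). Together with a number 2.20 log units higher from compound 1 to compound 3 (beyond the scatter), these steps rank the three groups on this carbon, in this configuration as drawn: 1H-1,2,3-triazol-1-yl gives the lowest number, 1,3-thiazol-2-yl an intermediate one and 4-fluorophenyl the highest. The series also gains its first reading at the stereocentre on the saturated ring carbon, with no change at the digits printed from compound 2 to compound 4 (within the scatter), and that step reads as one of configuration alone, on this ground: the fact that compounds 2 and 4 differ only in the configuration as drawn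

Whether configuration leaves the number equally unchanged with 4-fluorophenyl or 1H-1,2,3-triazol-1-yl on the aromatic carbon stays open, as the only such pair shown carries 1,3-thiazol-2-yl. Also open is where an amine, a carboxylic acid or a short alkyl chain on this aromatic carbon, ortho to a large group and meta to a trifluoromethyl group, would fall relative to the three groups shown.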